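Adding a chlorine to a biaryl amine: an expected binding constant

The source may hold more compounds than are shown below. What is called first, only, known or untested is meant among the compounds shown, and "the series" means these compounds.

Compound 1 `COc1ccccc1-c1cccc(CN(C)C)c1` is a biaryl carrying a methoxy group on one ring and a (dimethylamino)methyl group on the other. In an assay on HEK293 cells for displacement of a labelled ligand from 5-hydroxytryptamine receptor 7 (Homo sapiens), read by scintillation counting, with a stated time of 1.5 h, in the absence of a further agent (a higher number here means a weaker inhibitor, a lower number a stronger inhibitor), compound 1 gives 126 nM. Its companion, compound 2 `CNCc1cccc(-c2ccccc2OC)c1`, differs only at the amine nitrogen; in this assay compound 2 gives 226 nM. Within the data shown here, the step of a 1.8-fold higher number from compound 1 to compound 2 (0.25 log units; within the scatter) is the only measured step here. Compound 1 has the lowest of the two numbers, and compound 2 is the nearest, yet that gap is within the scatter.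

Compound 3 `COc1ccccc1-c1cc(CN(C)C)ccc1Cl` is to be tested in this assay. The change from compound 1 is chloro in place of hydrogen on an aromatic carbon. Among the measured compounds shown here, no measured step touches this position, since the one step, a 1.8-fold higher number from compound 1 to compound 2 (0.25 log units; within the scatter), concerns the amine and was itself within the scatter. Accordingly, no change beyond the scatter is expected, and the step of a 1.2-fold higher number from compound 1 to compound 3 (0.08 log units; within the scatter) is the estimate. Compound 3 is therefore expected to give 150 nM, within a range from 50 nM to 450 nM.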

Compound 3, inhibition constant: 18 nM
For compound 3 the middle estimate is 8.3-fold (0.92 log units) above the measured one; the whole stated range lies above it.
By their numbers in this assay, from the lowest: compound 3; then compounds 1 and 2 (each within the scatter of the next).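

Hydrogen to chloro on this aromatic carbon, para to a (dimethylamino)methyl group and ortho to a group of 8 heavy atoms, gives a 7.0-fold lower number from compound 1 to compound 3 (0.85 log units; beyond the scatter) in this assay, and a lower number here means a stronger inhibitor. Among these compounds, the only earlier step, at the amine nitrogen, stayed within the scatter, whereas this one lies beyond it, so this position on the aromatic ring is one where a change of a single heavy atom clearly alters binding. Nothing measured at hand explains why the number falls.

Going by these compounds, whether fluoro, bromo or methyl at this same position would lower the number as chloro does remains open. So does whether chloro would give a similar step on compound 2, with its single methyl on the amine nitrogen.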